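A few compounds are considered here, and "the series" means these few. Any claim that something is new, unique, unknown or untested is made for them only; others in the source may bear on it.

The compounds examined share one core, carrying a substituted amino group on the ring and a benzyl group on the triazole. In a functional assay on MGC-803 cells (Homo sapiens) for inhibition, read by MTT assay, with a stated time of 72 h (a lower number here means a stronger inhibitor, a higher number a weaker inhibitor), compound 1 `Cc1ccc(Nc2nc(SCc3cn(Cc4ccc(F)cc4)nn3)nc(-c3ccccc3)c2C#N)cc1` gives > 64000 nM, which is a limit and not a number. Compound 1 therefore stands at the limit of > 64000 nM in this assay, at which 1 of the 2 values shown sits. Among the compounds with values here, compound 2 `Cc1ccc(Cn2cc(CSc3nc(Nc4ccccc4F)c(C#N)c(-c4ccccc4)n3)nn2)cc1` gives 22900 nM in this assay, and this is the only numerical value available. Compound 3 `Cc1ccc(Cn2cc(CSc3nc(Nc4ccc(C)cc4)c(C#N)c(-c4ccccc4)n3)nn2)cc1` is not yet measured and differs from compound 2 by 4-methylphenyl in place of 2-fluorophenyl on a nitrogen on an aromatic ring. Within the data shown here, no step between measured compounds covers this exchange. Compound 1 also carries the (4-methylphenyl)amino group, though with a different benzyl group, and shows only a limit where compound 2 shows a number; with two differences between them, that pair cannot be read as a single step. The change is expected to weaken inhibition beyond the scatter, by about a 2.0-fold higher number from compound 2 to compound 3 (0.29 log units; within the scatter). Compound 3 is estimated at 45000 nM, in a range from 15000 nM to 150000 nM, with a fair chance that only a limit is returned.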

Compound 3, half-maximal inhibitory concentration: > 64000 nM
Compound 3 ended at the assay's limit; the forecaster's own chance of this, stated with the estimate: 40%; at least 1.4-fold (0.15 log units) between middle value and limit.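

Within the data shown here, at the nitrogen on an aromatic ring, 4-methylphenyl in place of 2-fluorophenyl gives an at least 2.7-fold higher number from compound 2 to compound 3 (0.44 log units; beyond the scatter) in this assay, the first step that can be read at this position. Compound 3 gives > 64000 nM, which is a limit and not a number. The step from compound 1 to compound 3, methyl in place of fluoro on an aromatic carbon, cannot be read, and the two compounds that carry the (4-methylphenyl)amino group are the two that sit at the limit: the limit of > 64000 nM in this assay, at which 2 of the 3 values shown sit.

Among these compounds, compound 2 holds the only numerical value, and the two groups exchanged at this nitrogen differ in their substituent and in where it sits, so these compounds cannot tell whether the loss of the fluoro group, the arrival of the methyl group or the change of place accounts for the step. Plain phenyl, 2-methylphenyl or 4-fluorophenyl on that nitrogen would separate these readings, and whether any group there gives a value well below that of compound 2, 22900 nM, remains open.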